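The source may report more compounds than this note shows. Statements on the series, on what has been measured and on what is new or still open speak of the compounds shown alone.

In a functional assay on SH-SY5Y cells (Homo sapiens) for cytotoxicity, read by MTT assay, with a stated time of 72 h (on this read-out lower numbers stand for stronger inhibition and higher numbers for weaker inhibition), compound 3 `O=C1c2c[n+]([O-])c3ccccc3c2C(=O)c2c1c1ccccc1n2CCCCN1CCCCC1`, which carries a 4-(piperidin-1-yl)butyl chain on the shared core, gives 230 nM. Compound 1 `CC1(C)OCC(Cn2cc(Cn3c4c(c5ccccc53)C(=O)c3c[n+]([O-])c5ccccc5c3C4=O)nn2)O1` shows the same figure at 230 nM, and compound 2 `CC1(C)OC[C@H](Cn2cc(Cn3c4c(c5ccccc53)C(=O)c3c[n+]([O-])c5ccccc5c3C4=O)nn2)O1` gives 820 nM. For the measured compounds named here, compound 3 therefore stands level with compound 1 at the low end of the numbers so far, and lower numbers here mean stronger inhibition.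

Compound 4 `O=C1c2c[n+]([O-])c3ccccc3c2C(=O)c2c1c1ccccc1n2Cc1cn(C[C@@H](O)CO)nn1` has not yet been measured. It differs from compound 3 by 1-(2,3-dihydroxypropyl)-1H-1,2,3-triazol-4-yl in place of 3-(piperidin-1-yl)propyl on a saturated chain carbon bound to an aromatic nitrogen. In words, 1-(2,3-dihydroxypropyl)-1H-1,2,3-triazol-4-yl takes the place of 3-(piperidin-1-yl)propyl.

Going by the values given here, the only measured step is a 3.6-fold higher number from compound 1 to compound 2 (0.55 log units; beyond the scatter), and it comes with the fact that one of compounds 1 and 2 is drawn with a defined configuration and the other without, at the place where they differ. This step does not test the swap itself, so it serves only as a rough guide to scale. Compounds 1 and 2 also hold a five-membered aromatic ring with 3 hetero atoms in their side chains, but neither carries the 2,3-dihydroxypropyl group. With compound 3 at 230 nM and compound 2 at 820 nM, a modest rise is the more likely direction, though no measurement tests it.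

The expected change is a 2.6-fold higher number from compound 3 to compound 4 (0.42 log units; beyond the scatter), an estimate of similar size to the measured step. Compound 4 is estimated at 600 nM, with an expected range from 170 nM to 2500 nM.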

Compound 4, half-maximal inhibitory concentration: > 500 nM
Compound 4: only a limit was reported; the forecaster's own chance of this, stated with the estimate: 5%; the middle value is on the limit's open side.
By their numbers in this assay, from the lowest: compounds 1 and 3 (each within the scatter of the next); then compound 2.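

In this assay compound 4 gives > 500 nM, which is a limit of the assay and not a number. Even so, the limit gives a direction at this place, a saturated chain carbon bound to an aromatic nitrogen: putting 1-(2,3-dihydroxypropyl)-1H-1,2,3-triazol-4-yl in place of 3-(piperidin-1-yl)propyl gives an at least 2.1-fold higher number from compound 3 to compound 4 (0.33 log units; beyond the scatter). Compound 1 already holds the five-membered aromatic ring, so its comparison isolates the outer end of the side chain, 1,2-dihydroxyethyl in place of 2,2-dimethyl-1,3-dioxolan-4-yl, and gives an at least 2.1-fold higher number from compound 1 to compound 4 (0.33 log units; beyond the scatter), while the step from compound 2 to compound 4 cannot be read against the limit, so this weakening holds against compounds 1 and 3 only.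

As far as these compounds go, how far the true value of compound 4 lies past the limit stays open, and with it whether the free diol differs at all from the protected form in compound 2. Also open, from the compounds shown here alone, is whether a carboxylic acid on the five-membered ring, or a longer chain ending in the two hydroxyl groups, would bring the number back towards that of compound 3 at 230 nM.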